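Notes on the step from compound 3 to compound 4

The compounds below may be only part of what the source reports. "The series", "measured", "known", "first", "only" and "open" are said of these compounds alone.

compound 1 `COc1ccc(-c2c(Nc3ccc(NC(C)=O)cc3)c3ccc(OC)cc3oc2=O)cc1`: > 100000 nM
compound 2 `COc1ccc(Nc2c(C(=O)C(F)(F)F)c(=O)oc3ccc(OC)cc23)cc1`: > 100000 nM
compound 3 `COc1ccc2oc(=O)c(C(=O)C(F)(F)F)c(Nc3ccc(F)cc3)c2c1`: > 100000 nM
compound 4 `COc1ccc2oc(=O)c(C(=O)C(F)(F)F)c(Nc3ccc(C)c(O)c3)c2c1`: not yet measured

Each of the three values is a limit and not a number. In a functional assay on HepG2 cells (Homo sapiens) for antiproliferative activity, read by MTT assay, with a stated time of 48 h (a lower number here means a stronger inhibitor, a higher number a weaker inhibitor), compound 3 gives > 100000 nM, which is a limit. It shares that position with the other two measured compounds: the limit of > 100000 nM in this assay, at which 3 of the 3 values shown sit.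

The change to compound 4 is 3-hydroxy-4-methylphenyl in place of 4-fluorophenyl on a nitrogen on an aromatic ring, with 3-hydroxy-4-methylphenyl in place of 4-fluorophenyl on a nitrogen on an aromatic ring. Among the compounds with values here, the one measured step that bears on it is a step that the two limits leave unreadable from compound 2 to compound 3, with fluoro in place of methoxy on an aromatic carbon. Within the data shown here, that step offers no size to carry over, and no compound so far has given a number in this assay. No step beyond the scatter is therefore expected, and a further limit is the likeliest result. The expected change is a number no higher from compound 3 to compound 4 (the limit leaves the size open). For compound 4 the estimated value is 100000 nM, with an expected range of 30000 nM to 200000 nM.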

Compound 4, half-maximal inhibitory concentration: 6710 nM
Beside the measured number, compound 4's estimate is 15-fold (1.17 log units) above it; measured number below the stated range.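

In this assay, the group on the nitrogen turns out to be able to move the read-out: 3-hydroxy-4-methylphenyl in place of 4-fluorophenyl gives an at least 14-fold lower number from compound 3 to compound 4 (1.17 log units; beyond the scatter), and the same group in place of 4-methoxyphenyl gives an at least 14-fold lower number from compound 2 to compound 4 (1.17 log units; beyond the scatter). Within the data shown here, the shared core with a substituted phenyl on this nitrogen is therefore not inactive as such, which the earlier compounds could not show. Compound 4 alone gives a number, and the others remain at a limit: the limit of > 100000 nM in this assay, at which 3 of the 4 values shown sit.

The compounds shown do not separate the hydroxy group from the methyl group, since neither 3-hydroxyphenyl nor 4-methylphenyl appears on this nitrogen. Also open, on these data alone, is whether an amine or a carboxylic acid in place of the hydroxy group would keep a measurable value.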